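A few compounds are considered here, and "the series" means these few. Any claim that something is new, unique, unknown or untested is made for them only; others in the source may bear on it.

Compound 1 `N#Cc1ccc2[nH]c(-c3ccc4[nH]c(-c5ccc6[nH]cnc6c5)nc4c3)nc2c1` is the starting point in a functional assay on RPMI 8402 cells (Homo sapiens) for cytotoxicity; on this read-out higher numbers stand for weaker inhibition and lower numbers for stronger inhibition. In this assay compound 1 gives > 25000 nM, which is a limit of the assay and not a number. As far as these compounds go, it therefore sits at the limit of > 25000 nM in this assay, at which 1 of the 2 values shown sits, and how far its true value lies beyond that limit is unknown.

Compound 2 `c1ccc(-c2ccc3[nH]c(-c4ccc5[nH]c(-c6ccc7[nH]cnc7c6)nc5c4)nc3c2)cc1` carries phenyl in place of cyano on an aromatic carbon, and compound 2 gives 580 nM. That single measured change is an at least 43-fold lower number from compound 1 to compound 2 (1.63 log units; beyond the scatter), a large step.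

Compound 3 `c1ccc2[nH]c(-c3ccc4[nH]c(-c5ccc6[nH]cnc6c5)nc4c3)nc2c1` has not yet been measured. It differs from compound 1 by hydrogen in place of cyano on an aromatic carbon. The measured step is the only one that bears on this change, since it removes the same cyano from the same place. Hydrogen is not phenyl, however, so that step may not carry over in full.

The expected result is a lower number, probably by a smaller margin, and the estimate is an at least 8.3-fold lower number from compound 1 to compound 3 (0.92 log units; beyond the scatter). For compound 3 the estimated value is 3000 nM, with an expected range of 600 nM to 20000 nM.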

Compound 3, half-maximal inhibitory concentration: 28000 nM
Beside the measured number, compound 3's estimate is 9.3-fold (0.97 log units) below it; the whole stated range lies below it.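

With hydrogen in place of phenyl on this aromatic carbon of the core, this assay shows a 48-fold higher number from compound 2 to compound 3 (1.68 log units; beyond the scatter), so the low number of compound 2 goes with the phenyl group itself and not simply with the absence of cyano. The step from compound 1 to compound 3 cannot be read, because the value of compound 1 is a limit of the assay and not a number: the limit of > 25000 nM in this assay, at which 1 of the 3 values shown sits. Within the data shown here, whether cyano and hydrogen differ at this position therefore stays unsettled, and phenyl is the only one of the three groups for which a readable step shows a change.

As far as these compounds go, it remains open whether the lower number needs an aromatic ring at this carbon, or whether a saturated cyclohexyl ring or a simple methyl group would go with a similar value. Also open, from the compounds shown here alone, is how an amine, a carboxylic acid or a methoxy group on the phenyl ring would read in this assay, and whether a pyridine ring could stand in for the phenyl.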